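The source may report more compounds than this note shows. Statements on the series, on what has been measured and on what is new or still open speak of the compounds shown alone.

Compound 1 `COc1ccc(C(=O)c2cc(OC)c(OC)c(OC)c2)cc1N` gives 80 nM in a functional assay on ME-180 cells (Homo sapiens) for cytotoxicity, read by MTT assay, with a stated time of 72 h; a lower number here means a stronger inhibitor, a higher number a weaker inhibitor. Compound 2 `COc1ccc(C(=O)c2cc(OC)c(OC)c(OC)c2)cc1NC(=O)/C=C/c1cc(OC)c(OC)c(OC)c1` gives 2100 nM. Compound 3 `COc1cc(C(=O)c2cc(OC)c(OC)c(OC)c2)cc(NC(=O)/C=C/c2cc(OC)c(OC)c(OC)c2)c1OC` gives 3900 nM.

Compound 3 holds the highest number of the three; its nearest neighbour is compound 2, and the step of a 1.9-fold higher number from compound 2 to compound 3 (0.27 log units; within the scatter) lies within the scatter, while compound 1 stands far lower. Compound 4 `COc1cc(C(=O)c2cc(OC)c(OC)c(OC)c2)cc(NC(=O)/C=C/c2ccc(F)cc2)c1OC` differs from compound 3 in one place: 4-fluorophenyl in place of 3,4,5-trimethoxyphenyl on a double-bonded chain carbon bound to a double-bonded chain carbon. Among the compounds with values here, no measured step touches this place; the only measured step concerns a methoxy on the core and was small. With no guide in the data, compound 4 is expected to stay close to compound 3, so the expected step of a 1.3-fold lower number from compound 3 to compound 4 (0.11 log units; within the scatter) is none beyond the scatter. The estimate for compound 4 in this assay is 3000 nM, ranging from 600 nM to 15000 nM.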

Compound 4, half-maximal inhibitory concentration: 1000 nM
Estimate against measurement, compound 4: 3.0-fold (0.48 log units) above, and the stated range covers the measured number.
By their numbers in this assay, from the lowest: compound 1; then compound 4; then compounds 2 and 3 (each within the scatter of the next).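

Within the data shown here, the change on the double-bonded chain carbon moves the number further than the one earlier step, which concerned a methoxy on the core and stayed within the scatter: 4-fluorophenyl in place of 3,4,5-trimethoxyphenyl gives a 3.9-fold lower number from compound 3 to compound 4 (0.59 log units; beyond the scatter). So this position responds to its aromatic group, and the three methoxy groups are not needed to keep the number at this level. Nothing shown explains why the number falls. The compounds shown leave open whether the fluorine or the loss of the methoxy groups matters more; a plain phenyl or a 4-methoxyphenyl here could separate the two.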